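The source may hold more compounds than are shown below. What is called first, only, known or untested is meant among the compounds shown, and "the series" means these compounds.

Compound 3 `CCCCCCCCCCCCCCCCSC[C@H](NC(C)=O)C(=O)CCl` sits at the upper end of the three numbers measured in a functional assay on MOLT-3 cells (Homo sapiens) (a higher number here means a weaker inhibitor, a lower number a stronger inhibitor), where compound 3 gives 17300 nM; its distance from compound 1 lies beyond the scatter, its distance from compound 2 within it. Compound 1 `CCCCCCCCCCCCSC[C@H](NC(C)=O)C(=O)CCl` gives 2300 nM and compound 2 `CCCCCCCCCCCCCCSC[C@H](NC(C)=O)C(=O)CCl` gives 8800 nM. Compound 4 `CCCCCCCCCCCCCCCCCCSC[C@H](NC(C)=O)C(=O)CCl` differs from compound 3 by ethyl in place of hydrogen on a saturated chain carbon, ten or more bonds along the chain from a sulfur. The same change has been made twice along this chain, giving a 3.8-fold higher number from compound 1 to compound 2 (0.58 log units; beyond the scatter) and a 2.0-fold higher number from compound 2 to compound 3 (0.29 log units; within the scatter), and over both steps together a 7.5-fold higher number from compound 1 to compound 3 (0.88 log units; beyond the scatter). A further step in the same direction is therefore expected in this assay, probably modest, estimated as a 1.7-fold higher number from compound 3 to compound 4 (0.24 log units; within the scatter). Compound 4 is expected to give about 30000 nM, with a range of 12000 nM to 75000 nM.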

Compound 4, half-maximal inhibitory concentration: > 100000 nM
Compound 4 gave a limit, no number (the forecaster's own chance of this, stated with the estimate: 15%); middle value at least 3.3-fold (0.52 log units) from the limit.
By their numbers in this assay, from the lowest: compound 1; then compounds 2 and 3 (each within the scatter of the next). At a limit, above all of these: compound 4.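

In this assay compound 4 reads only as a limit, > 100000 nM, not a number. Adding ethyl once more gives an at least 5.7-fold higher number from compound 3 to compound 4 (0.76 log units; beyond the scatter), so the trend does not level off after a 2.0-fold higher number from compound 2 to compound 3 (0.29 log units; within the scatter), and the same change can be compared on two cores: the same change on two cores in this assay, a 3.8-fold higher number (0.58 log units; beyond the scatter) from compound 1 to compound 2 and an at least 5.7-fold higher number (0.76 log units; beyond the scatter) from compound 3 to compound 4; the limit leaves it open whether they differ Lengthening by butyl gives an at least 11-fold higher number from compound 2 to compound 4 (1.05 log units; beyond the scatter) and by hexyl gives an at least 43-fold higher number from compound 1 to compound 4 (1.63 log units; beyond the scatter), so no compound of the four goes against the direction, longer chain and higher number.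

The limit leaves the full size of these steps open. Going by these compounds, whether a shorter chain continues the trend, and what an amine on the saturated chain would do, also stay open.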